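The compounds below may be only part of what the source reports. "The series", "measured", "known", "first", "only" and "open" are said of these compounds alone.

Compound 3, whose structure is `COc1ccc(/C=C2\CCC/C(=C\c3ccccc3Br)C2=O)cc1OC`, gives 8400 nM in a functional assay on HT-1080 cells (Homo sapiens) for cytotoxicity, read by MTT assay, with a stated time of 72 h (a lower number here means a stronger inhibitor, a higher number a weaker inhibitor), and sits as the lowest of the two numbers in hand. Its nearest neighbour is compound 1, `COc1cccc(/C=C2\CCC/C(=C\c3ccccc3Br)C2=O)c1OC`, which in this assay gives 10800 nM, a gap that lies within the usual scatter. Compound 2, `COc1cccc(/C=C2\CCC/C(=C\c3ccc(O)cc3)C2=O)c1OC`, is reported in this assay only as a limit of > 20000 nM, with no number. Within the data shown here, the single measured step, an at least 1.8-fold higher number from compound 1 to compound 2 (0.26 log units; that floor lies within the scatter), also leaves only a limit rather than a number, as noted by the limit of > 20000 nM in this assay, at which 1 of the 3 values shown sits.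

Compound 4, `COc1ccc(/C=C2\CCC/C(=C\c3ccc(Cl)cc3Cl)C2=O)cc1OC`, differs from compound 3 by 2,4-dichlorophenyl in place of 2-bromophenyl on a double-bonded chain carbon bound to a double-bonded ring carbon. Among the measured compounds shown here, no measured step exchanges one halogenated phenyl for another on that carbon, so the step from compound 1 to compound 2 bears on it only loosely. The halogen is retained here, so compound 4 is expected to stay close to compound 3, with a step of a 1.2-fold lower number from compound 3 to compound 4 (0.08 log units; within the scatter) that remains within the scatter. Compound 4 is therefore estimated at 7000 nM in this assay, within a range from 3000 nM to 16000 nM.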

Compound 4, half-maximal inhibitory concentration: 10500 nM
Compound 4: the middle estimate sits 1.5-fold (0.18 log units) below what was measured; the range from low to high includes it.
By their numbers in this assay, from the lowest: compounds 3, 4 and 1 (each within the scatter of the next). At a limit, above all of these: compound 2.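

Replacing 2-bromophenyl with 2,4-dichlorophenyl on a double-bonded chain carbon bound to a double-bonded ring carbon changes the heavy-atom count and the halogen, yet the two compounds remain within the scatter of each other in this assay (a 1.3-fold higher number from compound 3 to compound 4 (0.10 log units; within the scatter)). Unlike the only earlier step at this place, this one has a number at both ends, so its size can be read directly. Nothing among the compounds shown gives a reason for this step.

The compounds shown leave open how a phenyl carrying an amine or a carboxylic acid would read at this place in this assay. They also leave open whether 2,4-dichlorophenyl would read the same on the core of compound 1, where only 2-bromophenyl and 4-hydroxyphenyl appear.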